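Working notes: from compound 3 to compound 4

This account rests on a few compounds, and the source may have more. Where it says the series, first, only, none or still open, it means among the compounds named here.

Measured so far in a physicochemical assay for lipophilicity, at pH 7.4 (a lower number here means a more polar compound, a higher number a more lipophilic compound), are these compounds:
Compound 1 `CCc1ccc(N(CC(C)C)S(=O)(=O)c2ccc(OCC3CCOCC3)c3c2CCCC3=O)cc1` gives 4.84
Compound 2 `CC(C)CN(c1cccc(F)c1)S(=O)(=O)c1ccc2c(c1)C(=O)CC(C1CCOCC1)O2` gives 3.5
Compound 3 `Cc1ccc(N(CC(C)C)S(=O)(=O)c2ccc3c(c2)C(=O)CC(C2CCOCC2)O3)c(C)c1` gives 4.28

Compound 3 (4.28) stands second highest of the three numbers, with compound 1 (4.84) higher and compound 2 (3.5) lower, both gaps beyond the scatter. Compound 4 `CC(C)CN(c1cc2ccccc2s1)S(=O)(=O)c1ccc2c(c1)C(=O)CC(C1CCOCC1)O2` is not yet measured. It differs from compound 3 by 1-benzothiophen-2-yl in place of 2,4-dimethylphenyl on a sulfonamide nitrogen. For the measured compounds named here, one measured step bears on this place: a number 0.78 log units higher from compound 2 to compound 3 (beyond the scatter) is modest and beyond the scatter, with 2,4-dimethylphenyl in place of 3-fluorophenyl on a sulfonamide nitrogen. Going by the values given here, that single step shows a modest shift in this assay at this place, yet no measured compound carries 1-benzothiophen-2-yl, and the direction remains open. The expected change is a number 0.12 log units higher from compound 3 to compound 4 (within the scatter) with no step beyond the scatter foreseen. Compound 4 is estimated at 4.4 with an expected range from 3.9 to 4.9 for a single measurement.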

Compound 4, distribution coefficient: 4.01
Estimate against measurement, compound 4: 0.39 log units above; measured number inside the range.
By their numbers in this assay, from the lowest: compound 2; then compounds 4 and 3 (each within the scatter of the next); then compound 1.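

For the compounds shown here, the exchange of 2,4-dimethylphenyl for 1-benzothiophen-2-yl on a sulfonamide nitrogen gives the first step at this place in this assay that stays inside the scatter: a number 0.27 log units lower from compound 3 to compound 4 (within the scatter). Measured against 3-fluorophenyl, the same group gives a number 0.51 log units higher from compound 2 to compound 4 (beyond the scatter), so compound 2 is now separated from two different replacements, and the two aromatic groups, one of them carrying sulfur in a five-membered ring, cannot be told apart in this assay. Nothing on hand accounts for these numbers.

As far as these compounds go, what a saturated ring such as cyclohexyl, or an aromatic ring bearing an amine or a carboxylic acid, would give at this place remains open. Also open, from the compounds shown here alone, is whether these steps would hold on the core of compound 1.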